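A few compounds are considered here, and "the series" means these few. Any claim that something is new, unique, unknown or untested is made for them only; others in the source may bear on it.

Compound 1 `COc1ccc(/C=C/C(=O)c2ccc(OC)c3c2OC(C)(C)C=C3)cc1O` was tested in a functional assay on HepG2 cells (Homo sapiens) for cytotoxicity, read by MTT assay (on this read-out lower numbers stand for stronger inhibition and higher numbers for weaker inhibition), where compound 1 gives 450 nM, the second highest of the three numbers. Compound 2 `COc1ccc(/C=C/C(=O)c2ccc(OC)c3c2OC(C)(C)C=C3)cc1OC(=O)C1CC1` gives 220 nM and compound 3 `COc1cccc(C(=O)Oc2cc(/C=C/C(=O)c3ccc(OC)c4c3OC(C)(C)C=C4)ccc2OC)c1` gives 870 nM. The step of a 2.0-fold lower number from compound 1 to compound 2 (0.31 log units; beyond the scatter) lies beyond the scatter, whereas a 1.9-fold higher number from compound 1 to compound 3 (0.29 log units; within the scatter) stays within it. Compound 4 `COc1ccc(/C=C/C(=O)c2ccc(OC)c3c2OC(C)(C)C=C3)cc1OS(=O)(=O)c1ccc(C)cc1` carries the change ((4-methylphenyl)sulfonyl in place of hydrogen on an oxygen on an aromatic ring). Both earlier steps put a group on the same oxygen on an aromatic ring; the small cyclopropylcarbonyl gave a modestly lower number, while the (3-methoxyphenyl)carbonyl, which also brings an aromatic ring, left the number within the scatter. With the entering (4-methylphenyl)sulfonyl also bearing an aromatic ring, compound 4 is expected to show a step of a 1.4-fold higher number from compound 1 to compound 4 (0.16 log units; within the scatter), likely within or barely beyond the scatter. The estimate for compound 4 is 650 nM, ranging from 250 nM to 1700 nM.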

Compound 4, half-maximal inhibitory concentration: 3600 nM
Compound 4: the middle estimate sits 5.5-fold (0.74 log units) below what was measured; measured number above the stated range.
By their numbers in this assay, from the lowest: compound 2; then compounds 1 and 3 (each within the scatter of the next); then compound 4.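

In this assay, a group on this oxygen on an aromatic ring can clearly weaken inhibition: the (4-methylphenyl)sulfonyl gives an 8.0-fold higher number from compound 1 to compound 4 (0.90 log units; beyond the scatter), a rise beyond the scatter that neither carbonyl-linked group produced. An aromatic ring in the entering group does not by itself set the number, as the sulfonyl group still gives a 4.1-fold higher number from compound 3 to compound 4 (0.62 log units; beyond the scatter), and the contrast with the cyclopropylcarbonyl is a 16-fold higher number from compound 2 to compound 4 (1.21 log units; beyond the scatter). Nothing available here explains these differences. As far as these compounds go, it remains open how a methanesulfonyl or an acetyl would read here, so the sulfonyl link and the 4-methylphenyl cannot be separated.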